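Cytotoxicity notes on the shared-core aryl ether series

This account rests on a few compounds, and the source may have more. Where it says the series, first, only, none or still open, it means among the compounds named here.

In an ADME assay on MT4 cells (Homo sapiens) for cytotoxicity, read by MTT assay, with a stated time of 4 days (a higher number here means that more compound is tolerated, a lower number that less compound is tolerated), compound 1 `COc1cc(C#N)ccc1Oc1nc(Nc2ccc(C#N)cc2)nc2ccccc12` is recorded only as a limit, >= 140000 nM, which is the limit of >= 140000 nM in this assay, at which 1 of the 2 values shown sits. In this assay, going by the values given here, compound 2 `Cc1cc(Br)cc(Br)c1Oc1nc(Nc2ccc(C#N)cc2)nc2ccccc12` gives 150000 nM, the only full number in the set, so its standing relative to compound 1 cannot be fixed. Among the compounds with values here, the single measured step, a step that the limit leaves unreadable from compound 1 to compound 2, is for the same reason of unreadable size. Compound 3 `Cc1ccc(Oc2nc(Nc3ccc(C#N)cc3)nc3ccccc23)cc1` carries the change (4-methylphenyl in place of 2,4-dibromo-6-methylphenyl on an oxygen on an aromatic ring). No readable measured step bears on this change, and nothing in the numbers shown argues for a shift beyond the usual scatter of this assay. Compound 3 is therefore expected to sit close to its neighbour, with an estimated step of no change at the digits printed from compound 2 to compound 3 (within the scatter). The estimate for compound 3 is 150000 nM, with a range from 60000 nM to 400000 nM, and a real chance that only a limit is reported.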

Compound 3, half-maximal cytotoxic concentration: 87000 nM
Compound 3: middle estimate off by 1.7-fold (0.24 log units), on the high side, within the range that was stated.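

Placing 4-methylphenyl in place of 2,4-dibromo-6-methylphenyl on the oxygen gives a 1.7-fold lower number from compound 2 to compound 3 (0.24 log units; within the scatter), the first step at this position with a readable size, and it shows that in this assay this position accepts a smaller group carrying no bromine without a shift beyond the scatter. Placing 4-methylphenyl in place of 4-cyano-2-methoxyphenyl gives an at least 1.6-fold lower number from compound 1 to compound 3 (0.20 log units; that floor lies within the scatter), which is a floor and not a full size. Compound 1 is recorded only as a limit, so the step from compound 1 to compound 2 cannot be read: the limit of >= 140000 nM in this assay, at which 1 of the 3 values shown sits.

The compounds shown leave open whether a ring carrying an amine or a carboxylic acid, or a longer alkyl chain in place of the ring on the oxygen, would stay in this range in this assay. As far as these compounds go, how much of the step from the dibromo group belongs to the bromines alone also stays open.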